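The source may report more compounds than this note shows. Statements on the series, on what has been measured and on what is new or still open speak of the compounds shown alone.

Measured compounds in an in vivo ADME assay on the whole organism (strain Sprague-Dawley) for metabolic stability, with Rattus norvegicus as the target, at a dose of 10 mg/kg by the oral route; on this read-out higher numbers stand for a longer-lived compound and lower numbers for a shorter-lived compound:
- compound 1 `O=C1O[C@@H](Cn2ccnn2)CN1c1ccc(N2CCN(Cc3ccc([N+](=O)[O-])o3)CC2)c(F)c1`: 1.51 h
- compound 2 `O=C1O[C@@H](Cn2ccnn2)CN1c1ccc(N2CCN(Cc3cccc([N+](=O)[O-])c3)CC2)c(F)c1`: 2.36 h

Compound 2 is the reference point for the next step. Among the compounds with values here, its nearest neighbour in this assay is compound 1, and the two are within the scatter of each other: the one measured step, a 1.6-fold higher number from compound 1 to compound 2 (0.19 log units; within the scatter), is too small to count as a change.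

Compound 3 `O=C1O[C@@H](Cn2ccnn2)CN1c1ccc(N2CCN(Cc3ccoc3)CC2)c(F)c1` has not been measured in this assay. It differs from compound 2 in one place: furan-3-yl in place of 3-nitrophenyl on a saturated chain carbon bound to an amine nitrogen in a ring.

Within the data shown here, the only measured step that bears on this change is the one from compound 1 to compound 2, which also exchanged the aromatic group on the saturated chain carbon bound to the amine nitrogen in the ring, and that step stayed within the scatter. Among the measured compounds shown here, no measured pair shows a furan-3-yl group at this place, so the expectation rests on that single step alone. The working expectation is therefore a step in this assay of a 1.2-fold lower number from compound 2 to compound 3 (0.07 log units; within the scatter), that is, no change beyond the scatter in either direction.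

On that basis the half-life of compound 3 in this assay is estimated at 2 h, with a range from 1 h to 4 h.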

Compound 3, half-life: 2.76 h
Compound 3: middle estimate off by 1.4-fold (0.14 log units), on the low side, within the range that was stated.
By their numbers in this assay, from the lowest: compounds 1, 2 and 3 (each within the scatter of the next).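

In this assay, furan-3-yl in place of 3-nitrophenyl gives a 1.2-fold higher number from compound 2 to compound 3 (0.07 log units; within the scatter), so on a saturated chain carbon bound to an amine nitrogen in a ring, the group can go from 9 heavy atoms to 5 and lose its nitro group with no step beyond the scatter. The same furan-3-yl in place of 5-nitrofuran-2-yl gives a 1.8-fold higher number from compound 1 to compound 3 (0.26 log units; within the scatter), so the earlier reading of this place now extends to a group without a nitro group, and all three aromatic groups remain inseparable on half-life. Nothing available explains why the half-life holds across these exchanges.

Going by these compounds, all three groups at this place are aromatic rings, so it remains open whether a saturated ring such as cyclohexyl, or a carboxylic acid on the ring, would give a step beyond the scatter. On these data alone, it also remains open whether any change to the shared core away from this place would move the half-life further than these exchanges have.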